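Cyclopropyl to methyl: expected clearance of compound 4

The source may report more compounds than this note shows. Statements on the series, on what has been measured and on what is new or still open speak of the compounds shown alone.

Three compounds sharing one core have been run in an ADME assay on cells (Hepatocyte, Homo sapiens) for metabolic stability, read by LC-MS, with a stated time of 60 min, tested at 1 uM; on this read-out higher numbers stand for fast clearance and lower numbers for slow clearance. Compound 1 `COc1cc(N(CC2CC2)c2ccccc2)cnc1C(=O)[C@H]1C[C@@H]1C(=O)O` gives 3 uL/min. Compound 2 `CCN(c1cnc(C(=O)[C@H]2C[C@@H]2C(=O)O)c(OC)c1)c1ccc(F)c2ccccc12` gives 3.8 uL/min. Compound 3 `COc1cc(N(CC2CC2)c2cccc(C(F)(F)F)c2)cnc1C(=O)[C@H]1C[C@@H]1C(=O)O` gives 2.3 uL/min, the lowest of the three numbers, though its gap to compound 1 and its gap to compound 2 both lie within the scatter. The one single-point step measured so far, a 1.3-fold lower number from compound 1 to compound 3 (0.12 log units; within the scatter), is likewise within the scatter, so the series has not yet shown a change that moves this read-out.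

Compound 4 `CCN(c1cccc(C(F)(F)F)c1)c1cnc(C(=O)[C@H]2C[C@@H]2C(=O)O)c(OC)c1` differs from compound 3 by methyl in place of cyclopropyl on a saturated chain carbon bound to a nitrogen on an aromatic ring; cut one bond further out, the change reads cyclopropylmethyl to ethyl. Among the compounds with values here, no measured step addresses this change directly. Compound 2 also carries an ethyl group, but it differs from compound 3 in a second place as well, so only its value and that of compound 3 can be set side by side, and they fall within the scatter of each other.

With nothing in the data pointing either way, the step of a 1.2-fold higher number from compound 3 to compound 4 (0.09 log units; within the scatter) is expected to stay within the scatter. Compound 4 is therefore estimated at 2.8 uL/min, with a range from 1.4 uL/min to 5.6 uL/min.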

Compound 4, intrinsic clearance in a liver preparation (reported as CLH), per the amount of preparation that the assay uses in the Hepatocyte assay: 3.1 uL/min
Compound 4: the middle estimate sits 1.1-fold (0.04 log units) below what was measured; the measured number falls inside the stated range.
By their numbers in the Hepatocyte assay, from the lowest: compounds 3, 1, 4 and 2 (each within the scatter of the next).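

The cyclopropyl position now has a direct read in the Hepatocyte assay: a 1.3-fold higher number from compound 3 to compound 4 (0.13 log units; within the scatter), so methyl in place of cyclopropyl on this saturated chain carbon leaves clearance within the scatter. In a physicochemical assay for lipophilicity, read by LC-MS, in phosphate buffer, measured as octanol-water partition, at pH 7.4 (a higher number here means a more lipophilic compound, a lower number a more polar compound), compound 3 gives 1.4 and compound 4 gives 0.7, a gap beyond the scatter. The same single change therefore moves the distribution coefficient while the Hepatocyte assay shows no step beyond the scatter, the first sign in the series that the two read-outs can separate at this position.

From the compounds shown here alone, this rests on one pair carrying trifluoromethyl, so whether the change behaves alike without that group, as in compound 1, stays open. Also open, going by these compounds, is what a longer chain such as propyl, or a chain ending in a hydroxyl group, would give at this position on either read-out.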